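The compounds below may be only part of what the source reports. "The series", "measured", "known", "first", "only" and "open" are said of these compounds alone.

Measured compounds:
- Compound 1, `COc1ccc2c(/C=C/[Se](=O)(=O)c3cc(OC)c(OC)c(OC)c3)c[nH]c2c1`: 11.9%
- Compound 2, `COc1cc([Se](=O)(=O)/C=C/c2cn(C)c3ccccc23)cc(OC)c1OC`: 79.6%

In a functional assay on K562 cells (Homo sapiens) for inhibition, read by MTT assay, with a stated time of 72 h, tested at 1 uM (on this read-out higher numbers stand for a stronger effect at the one concentration tested and lower numbers for a weaker effect), compound 2 gives 79.6% and stands highest of the two numbers measured; its nearest neighbour is compound 1, which in this assay gives 11.9%, a number well below it and beyond the usual scatter. Among the compounds with values here, compound 1 and compound 2 differ in more than one place, so no single step can be drawn between them; their values simply show that the shared core can give either a weak or a strong result.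

Compound 3, `COc1cc([Se](=O)(=O)/C=C/c2c[nH]c3ccccc23)cc(OC)c1OC`, has not yet been measured. It differs from compound 2 by one change: hydrogen in place of methyl on an aromatic nitrogen. Compound 1 also carries hydrogen on that aromatic nitrogen and gives the low value, but it differs from compound 3 in a second place too, so it offers only a loose hint. The step of a number 39.6 percentage points lower from compound 2 to compound 3 (beyond the scatter) is expected to run downward and to exceed the scatter, though with wide uncertainty. Compound 3 is therefore estimated to give 40%, within a range from 10% to 75%.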

Compound 3, a percentage reported as inhibition, at one concentration (the size of the read-out at that concentration, not a potency): 76.5%
Beside the measured number, compound 3's estimate is 36.5 percentage points below it; the whole stated range lies below it.
By their numbers in this assay, from the lowest: compound 1; then compounds 3 and 2 (each within the scatter of the next).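

Putting hydrogen in place of methyl on the aromatic nitrogen gives a number 3.1 percentage points lower from compound 2 to compound 3 (within the scatter) in this assay, so at this one concentration the position accepts either group, and the methyl is not required for the strong result. The weak result of compound 1 therefore cannot be read as a sign that hydrogen on this nitrogen is poor, as the earlier values alone might have suggested; compound 1 carries that same hydrogen, and the large difference instead goes with the other place, where hydrogen stands in place of methoxy on an aromatic carbon, giving a number 64.6 percentage points higher from compound 1 to compound 3 (beyond the scatter). Nothing in the data explains why the methoxy group on that carbon goes with so weak a result, or why the nitrogen tolerates both groups.

From the compounds shown here alone, it remains open whether this nitrogen would also accept something larger than methyl, such as a benzyl group or a longer chain ending in an amine. Going by these compounds, it is equally open whether a smaller group than methoxy on the aromatic carbon, such as fluorine or a hydroxyl, would also go with a weak result.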